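This account rests on a few compounds, and the source may have more. Where it says the series, first, only, none or still open, it means among the compounds named here.

Three compounds have been measured so far (a functional assay on MIA PaCa-2 cells (Homo sapiens) for inhibition, read by MTT assay, with a stated time of 48 h, tested at 10 uM; a lower number here means less inhibition of growth, a higher number more inhibition of growth at the concentration tested):

- compound 1 (`Cc1cc(=O)c2c(O)cc(O)c([C@H]3CCN(C)C[C@H]3OC(=O)c3ccco3)c2o1`) (13%)
- compound 2 (`CCCCCCCCCC/C=C/c1c(C)oc2c([C@H]3CCN(C)C[C@H]3O)c(O)cc(O)c2c1=O`) (4%)
- compound 3 (`CN1CC[C@H](c2c(O)cc(O)c3c(=O)cc(/C=C/c4ccccc4)oc23)[C@H](O)C1`) (87%)

Among these three, compound 3 stands highest (87%). Compound 1 (13%) lies lower by a margin well beyond the usual scatter. Compound 2 (4%) lies further down still from compound 3, also beyond the scatter.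

The next compound to be tested is compound 4 (`CN1CC[C@H](c2c(O)cc(O)c3c(=O)cc(/C=C/c4ccccc4Cl)oc23)[C@H](O)C1`), which departs from compound 3 by one change (chloro in place of hydrogen on an aromatic carbon). It has chloro in place of hydrogen on an aromatic carbon, ortho to a large group, so that phenyl becomes 2-chlorophenyl and 2-phenylethenyl becomes 2-(2-chlorophenyl)ethenyl.

For the measured compounds named here, no pair of measured compounds differs in one place, so the data hold no direct precedent for this change. Compound 3 already reads high (87%), which leaves little room upward in this assay. A modest downward move is therefore expected, perhaps none beyond the scatter, although a larger fall cannot be ruled out. The estimated change is a number 9 percentage points lower from compound 3 to compound 4 (within the scatter). For compound 4 the expected value is 78%, with an estimated range of 50% to 95%.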

Compound 4, percent growth inhibition at one concentration: 59%
Compound 4: the middle estimate sits 19 percentage points above what was measured; the measured number falls inside the stated range.
By their numbers in this assay, from the lowest: compounds 2 and 1 (each within the scatter of the next); then compound 4; then compound 3.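

For the compounds shown here, the step gives the first one-place comparison in this set: in this assay chloro in place of hydrogen on an aromatic carbon, ortho to a large group, gives a number 28 percentage points lower from compound 3 to compound 4 (beyond the scatter) and so costs growth inhibition at this position. The loss is only partial, since compound 4, with its 2-(2-chlorophenyl)ethenyl group, still reads 59% in this assay and the position therefore accepts a chloro group without losing all inhibition at the concentration tested. No measurement on hand accounts for the fall, so it stands as an observation about this single change on this core.

The compounds shown leave open whether the fall belongs to chloro itself or would also follow another group at this place, such as fluoro, methyl, methoxy or an amine. They also leave open whether chloro elsewhere on the aromatic ring of the 2-phenylethenyl group would read as compound 4 does, so one step cannot yet be taken as a pattern for the ring as a whole.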